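Sulfonyl group change from compound 2 to compound 4

This account rests on a few compounds, and the source may have more. Where it says the series, first, only, none or still open, it means among the compounds named here.

- compound 1 `Cn1c(=O)c(S(=O)(=O)c2ccc(Cl)cc2Cl)cc2cnc(Nc3ccc4[nH]ccc4c3)nc21`: 1000 nM
- compound 2 `Cn1c(=O)c(S(=O)(=O)c2ccc(C(=O)O)cc2)cc2cnc(Nc3ccc4[nH]ccc4c3)nc21`: 10000 nM
- compound 3 `Cn1c(=O)c(S(=O)(=O)c2ccc(F)cc2)cc2cnc(Nc3ccc4occc4c3)nc21`: 5000 nM

In a functional assay on DU-145 cells (Homo sapiens) for inhibition, read by trypan blue exclusion, with a stated time of 72 h (on this read-out lower numbers stand for stronger inhibition and higher numbers for weaker inhibition), compound 2 gives 10000 nM. This is within the scatter of compound 3 at 5000 nM, and compound 1 at 1000 nM stands beyond the scatter on the lower side.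

The next compound is compound 4 `Cn1c(=O)c(S(=O)(=O)Cc2ccc(F)cc2F)cc2cnc(Nc3ccc4[nH]ccc4c3)nc21`, and the change is 2,4-difluorobenzyl in place of 4-carboxyphenyl on a sulfonyl sulfur.

For the measured compounds named here, one measured step bears on this place: a 10-fold higher number from compound 1 to compound 2 (1.00 log units; beyond the scatter), with 4-carboxyphenyl in place of 2,4-dichlorophenyl on a sulfonyl sulfur, beyond the scatter. Compound 1 also lacks the 4-carboxyphenyl, so removing that group may recover a lower number of similar size. The evidence is thin, resting on a single step. Going by the values given here, no measured compound carries a 2,4-difluorobenzyl, and compound 3 differs from the others in more than one place, so it gives no clean comparison.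

A clear move to a lower number is therefore expected in this assay. The expected change is a 10-fold lower number from compound 2 to compound 4 (1.00 log units; beyond the scatter). For compound 4 the estimated value is 1000 nM, with an expected range of 200 nM to 5000 nM.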

Compound 4, half-maximal inhibitory concentration: 1000 nM
Compound 4: middle estimate and measured number agree at the digits printed; the measured number falls inside the stated range.
By their numbers in this assay, from the lowest: compounds 1 and 4 (each within the scatter of the next); then compounds 3 and 2 (each within the scatter of the next).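

In this assay, for the compounds shown here, the 2,4-difluorobenzyl on the sulfonyl sulfur gives a 10-fold lower number from compound 2 to compound 4 (1.00 log units; beyond the scatter) and so provides a second replacement of the 4-carboxyphenyl that comes with a lower number, where the earlier compounds offered only the 2,4-dichlorophenyl. The lower number is therefore not tied to that one group, and the site accepts a benzyl as well as a directly attached aryl ring, with no change at the digits printed from compound 1 to compound 4 (within the scatter) when 2,4-difluorobenzyl stands in place of 2,4-dichlorophenyl. Nothing available accounts for the change in number on going from the 4-carboxyphenyl to either halogenated group.

The two halogenated groups differ in both their halogen and their link to the sulfonyl sulfur, so a 2,4-dichlorobenzyl or an unsubstituted benzyl would be needed to show whether either feature matters on its own. Going by these compounds, it also remains open whether the higher number of compound 2 goes with the carboxylic acid specifically, which a 4-carboxybenzyl or a 4-aminophenyl on the sulfonyl sulfur would help to separate.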